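This account rests on a few compounds, and the source may have more. Where it says the series, first, only, none or still open, it means among the compounds named here.

Compound 1 `O=C(CSc1nnnn1-c1cccc2ccccc12)N/N=C/c1ccco1` gives, in an ADME assay on MT4 cells (Homo sapiens) for cytotoxicity, read by MTT assay (on this read-out lower numbers stand for higher toxicity in this test and higher numbers for lower toxicity in this test), a limit of the assay: > 330000 nM. Among the measured compounds shown here, compound 2 `O=C(CSc1nnnn1-c1cccc2ccccc12)N/N=C/c1ccccc1Cl` gives the one number in this assay, 69700 nM. Compound 3 `O=C(CSc1nnnn1-c1cccc2ccccc12)N/N=C/c1ccc(F)cc1` also sits at a limit of this assay, > 307000 nM.

For the measured compounds named here, compound 2 therefore stands as the only measured number; the other two values are limits. The step of an at least 4.7-fold lower number from compound 1 to compound 2 (0.67 log units; beyond the scatter) and the step of an at least 4.4-fold higher number from compound 2 to compound 3 (0.64 log units; beyond the scatter) both show the 2-chlorophenyl compound as the lowest point, while the step that the two limits leave unreadable from compound 1 to compound 3 cannot be sized between two limits.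

Compound 4 `COc1cc(/C=N/NC(=O)CSc2nnnn2-c2cccc3ccccc23)ccc1O` differs from compound 2 in one place: 4-hydroxy-3-methoxyphenyl in place of 2-chlorophenyl on a carbon with a double bond to nitrogen. Both measured steps that bear on the change at this position, away from 2-chlorophenyl, moved to higher numbers in this assay, so a similar rise is expected for compound 4, a 3.6-fold higher number from compound 2 to compound 4 (0.55 log units; beyond the scatter), with a fair chance that only a limit is reported. Compound 4 is thus estimated at 250000 nM in this assay, within a range of 70000 nM to 400000 nM.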

Compound 4, half-maximal cytotoxic concentration: > 287000 nM
Compound 4: only a limit was reported; the forecaster's own chance of this, stated with the estimate: 55%; middle value at least 1.1-fold (0.05 log units) from the limit.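

With the change to 4-hydroxy-3-methoxyphenyl on a carbon with a double bond to nitrogen, this assay gives an at least 4.1-fold higher number from compound 2 to compound 4 (0.61 log units; beyond the scatter). Among the compounds shown here, this is a larger group with 1 hydrogen-bond donor and 2 hydrogen-bond acceptors, and it still leaves compound 2 as the lowest point and the only one with a number, now against three different replacements. Compound 4 sits at a limit of the assay: the limit of > 287000 nM in this assay, at which 1 of the 4 values shown sits.

The steps among compound 1, compound 3 and compound 4 cannot be read, so these three remain unordered. As far as these compounds go, it also remains open whether the low number of compound 2 would recur with a 4-chlorophenyl group, or whether a 2-fluorophenyl or 2-aminophenyl group at this position would lower the number as well.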